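A few compounds are considered here, and "the series" means these few. Any claim that something is new, unique, unknown or untested is made for them only; others in the source may bear on it.

Compound 1 `Cc1c(F)c(Oc2cccc(C(=N)N)c2)nc(Oc2cccc([N+](=O)[O-])c2)c1F` gives > 5000 nM in an assay on isolated protein for inhibition of serine protease 1 (Bos taurus) (a higher number here means a weaker inhibitor, a lower number a stronger inhibitor), a limit of the assay.
Compound 2 `Cc1c(F)c(Oc2cccc(C(=N)N)c2)nc(Oc2cccc(C(=O)O)c2)c1F` gives > 5000 nM in this assay, also a limit.
Compound 3 `Cc1c(F)c(Oc2cccc(OC(C)C)c2)nc(Oc2cccc(C(=N)N)c2)c1F` gives 2900 nM in this assay.

Among the measured compounds shown here, compound 3 is thus the only compound with an actual number; the two others sit at the limit of > 5000 nM in this assay, at which 2 of the 3 values shown sit. The steps of an at least 1.7-fold lower number from compound 1 to compound 3 (0.23 log units; that floor lies within the scatter) and an at least 1.7-fold lower number from compound 2 to compound 3 (0.23 log units; that floor lies within the scatter) are only floors and lie within the scatter, so no real change has been seen among these three.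

Compound 4 `Cc1c(F)c(Oc2cccc(CCC(=O)N(C)C)c2)nc(Oc2cccc(C(=N)N)c2)c1F` carries 2-(dimethylcarbamoyl)ethyl in place of isopropoxy on an aromatic carbon. For the measured compounds named here, none of the measured steps matches this change, so there is nothing to point a direction. Compound 4 is expected to stay close to compound 3, a step of a 1.0-fold higher number from compound 3 to compound 4 (0.01 log units; within the scatter), and its inhibition constant is estimated at 3000 nM, with a range from 800 nM to 8000 nM.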

Compound 4, inhibition constant: 4900 nM
The estimate for compound 4 lay 1.6-fold (0.21 log units) below the measured number; measured number inside the range.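

In this assay 2-(dimethylcarbamoyl)ethyl in place of isopropoxy gives a 1.7-fold higher number from compound 3 to compound 4 (0.23 log units; within the scatter). Among the compounds shown here, this is the one step here between two actual numbers rather than a floor. So on this aromatic carbon, these two quite different chains cannot be told apart, even though the new one is the longer. The steps of an at least 1.0-fold lower number from compound 1 to compound 4 (0.00 log units; that floor lies within the scatter) and an at least 1.0-fold lower number from compound 2 to compound 4 (0.00 log units; that floor lies within the scatter) are only floors within the scatter, since compound 1 and compound 2 carry only a limit: the limit of > 5000 nM in this assay, at which 2 of the 4 values shown sit.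

Going by these compounds, whether an amine or a still longer chain on this carbon would shift the number beyond the scatter stays open.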